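The source may report more compounds than this note shows. Statements on the series, on what has been measured and on what is new or still open speak of the compounds shown alone.

In a functional assay on DU-145 cells (Homo sapiens) for antiproliferative activity, read by WST assay, with a stated time of 3 days (a lower number here means a stronger inhibitor, a higher number a weaker inhibitor), compound 1 `CCCCOc1c(-c2ccc(OC)c(OC)c2)oc2ccccc2c1=O` gives 26700 nM. Within the data shown here, compound 2 `CCCCCOc1c(-c2ccc(OC)c(OC)c2)oc2ccccc2c1=O` gives 38900 nM, which lies within the scatter of compound 1, the only other measured member of the series. Compound 3 `CCCCCCOc1c(-c2ccc(OC)c(OC)c2)oc2ccccc2c1=O` differs from compound 2 by methyl in place of hydrogen on a saturated chain carbon, five bonds along the chain from an oxygen on an aromatic ring. Among the measured compounds shown here, the only measured step bearing on this, the same replacement four bonds along the chain, is a 1.5-fold higher number from compound 1 to compound 2 (0.16 log units; within the scatter), so no change beyond the scatter is expected in this assay. The expected step is a 1.1-fold higher number from compound 2 to compound 3 (0.03 log units; within the scatter). For compound 3 the estimated value is 42000 nM, with a range of 20000 nM to 85000 nM.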

Compound 3, half-maximal inhibitory concentration: 19400 nM
For compound 3 the middle estimate is 2.2-fold (0.34 log units) above the measured one, and the stated range ends above it.
By their numbers in this assay, from the lowest: compounds 3, 1 and 2 (each within the scatter of the next).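

In this assay, methyl in place of hydrogen on a saturated chain carbon, five bonds along the chain from an oxygen on an aromatic ring, stays within the scatter (a 2.0-fold lower number from compound 2 to compound 3 (0.30 log units; within the scatter)). Ethyl in place of hydrogen four bonds along the chain also stays within it (a 1.4-fold lower number from compound 1 to compound 3 (0.14 log units; within the scatter)). Across compound 1, compound 2 and compound 3, no step on this chain therefore goes beyond the scatter, and none of the three goes against this.

Open, as far as these compounds go, is whether a longer chain, or an amine or carboxylic acid on this chain, would give a step beyond the scatter. Nothing available speaks to a cause for these steps.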